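The compounds below may be only part of what the source reports. "The series", "measured", "known", "first", "only" and "open" are said of these compounds alone.

In a functional assay on NCI-H460 cells (Homo sapiens) for cytotoxicity, read by MTT assay, with a stated time of 24 h (on this read-out higher numbers stand for weaker inhibition and lower numbers for stronger inhibition), compound 1 `O=Cc1cc2ccccc2n(Cc2ccccc2)c1=O` is recorded only as a limit, > 100000 nM. Compound 2 `C#CCn1c(=O)c(C=O)cc2ccccc21` is also recorded only as a limit, > 100000 nM. Compound 3 `C#CCn1c(=O)c(C=O)cc2cc(Cl)ccc21` likewise has no number of its own, only the limit > 100000 nM. Going by the values given here, the series so far comes down to the limit of > 100000 nM in this assay, at which 3 of the 3 values shown sit.

Compound 4 `C#CCn1c(=O)c(C=O)cc2cc(F)ccc21` has fluoro in place of chloro on an aromatic carbon, with the rest of compound 3 unchanged: fluoro in place of chloro on an aromatic carbon. The measured change at that same place is a step that the two limits leave unreadable from compound 2 to compound 3. The change on the chain, a step that the two limits leave unreadable from compound 1 to compound 2, gives no size either. Neither step therefore supports a shift beyond the scatter in this assay, in either direction. The expected size is a number no higher from compound 3 to compound 4 (the limit leaves the size open), with no direction foreseen. Compound 4 is expected to be reported as a limit too because of the limit of > 100000 nM in this assay, at which 3 of the 3 values shown sit. For compound 4 the estimate is 100000 nM, within an expected range of 40000 nM to 200000 nM.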

Compound 4, half-maximal inhibitory concentration: > 100000 nM
Compound 4 was reported as a limit; the forecaster's own chance of this, stated with the estimate: 85%; the middle value lies on the limit itself.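

Compound 4 is recorded in this assay only as a limit, as are compound 2 and compound 3, so neither step to compound 4 can be read. The compounds shown leave open whether hydrogen, chloro or fluoro on that aromatic carbon changes cytotoxicity at all: the limit of > 100000 nM in this assay, at which 4 of the 4 values shown sit.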